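This account rests on a few compounds, and the source may have more. Where it says the series, first, only, none or still open, it means among the compounds named here.

All three measured compounds were tested in a functional assay on A549 cells (Homo sapiens) for antiproliferative activity, read by MTT assay, with a stated time of 72 h; a higher number here means a weaker inhibitor, a lower number a stronger inhibitor:

compound 1, `COc1cc(F)c(NC(=O)c2ccncc2OC)cc1Nc1nccc(-c2cn(C)c3ccccc23)n1`, gave 3430 nM
compound 2, `COc1ccc(C(=O)Nc2cc(Nc3nccc(-c4cn(C)c5ccccc45)n3)c(OC)cc2F)nc1`, gave 8200 nM
compound 3, `COc1cc(N(C)C)c(NC(=O)c2ccncc2OC)cc1Nc1nccc(-c2cn(C)c3ccccc23)n1`, gave 3030 nM

Compound 1 and compound 2 share a core and differ in one place: 5-methoxypyridin-2-yl in place of 3-methoxypyridin-4-yl on a carbonyl carbon. This change made a step of a 2.4-fold higher number from compound 1 to compound 2 (0.38 log units; beyond the scatter) in this assay. Compound 1 and compound 3 also differ in one place: dimethylamino in place of fluoro on an aromatic carbon. Here the step was a 1.1-fold lower number from compound 1 to compound 3 (0.05 log units; within the scatter), so the two values sit together. No direct comparison between compound 2 and compound 3 is made here beyond what their two values show.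

Compound 4, `COc1ccc(C(=O)Nc2cc(Nc3nccc(-c4cn(C)c5ccccc45)n3)c(OC)cc2N(C)C)nc1`, has not yet been measured. It differs from compound 3 by 5-methoxypyridin-2-yl in place of 3-methoxypyridin-4-yl on a carbonyl carbon. This is the same change as from compound 1 to compound 2, made at the same place, on a carbonyl carbon whose other neighbour is an amide-type nitrogen. The two cores differ by dimethylamino in place of fluoro on an aromatic carbon, a change that left the number in this assay essentially unmoved. Within the data shown here, on that basis the step from compound 3 to compound 4 is expected to resemble the earlier one, estimated at a 2.4-fold higher number from compound 3 to compound 4 (0.38 log units; beyond the scatter), because the only comparable step on record is a 2.4-fold higher number from compound 1 to compound 2 (0.38 log units; beyond the scatter). Compound 4 is therefore expected to give about 7300 nM in this assay, with a likely range from 3500 nM to 15000 nM, the width reflecting that this rests on a single earlier pair.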

Compound 4, half-maximal inhibitory concentration: 5150 nM
Estimate against measurement, compound 4: 1.4-fold (0.15 log units) above; the measured number falls inside the stated range.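

Placing 5-methoxypyridin-2-yl where 3-methoxypyridin-4-yl stood on the carbonyl carbon gives a 1.7-fold higher number from compound 3 to compound 4 (0.23 log units; within the scatter) in this assay, and the size of this step agrees with the one seen when the same change was made on the core carrying fluoro: the same change on two cores in this assay, a 2.4-fold higher number (0.38 log units; beyond the scatter) from compound 1 to compound 2 and a 1.7-fold higher number (0.23 log units; within the scatter) from compound 3 to compound 4, 1.4-fold (0.15 log units) apart, within the scatter of two such steps

The other change in this set of four, dimethylamino in place of fluoro on an aromatic carbon, gives a 1.6-fold lower number from compound 2 to compound 4 (0.20 log units; within the scatter), and it also carries over from one core to the other: the same change on two cores in this assay, a 1.1-fold lower number (0.05 log units; within the scatter) from compound 1 to compound 3 and a 1.6-fold lower number (0.20 log units; within the scatter) from compound 2 to compound 4, 1.4-fold (0.15 log units) apart, within the scatter of two such steps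

These matched steps show that, on these two closely related cores, each change has a similar size whichever core it is made on, but two pairs cannot establish a general rule, and the new pyridine step, taken alone, stays within the scatter and so does not confirm a real difference between compound 3 and compound 4.

From the compounds shown here alone, it remains open whether the same agreement would hold for other groups, such as a plain phenyl ring on the carbonyl carbon or a piperazine in place of dimethylamino on the aromatic carbon. The role of the methoxy group is also unsettled, and a hydroxy or ethoxy group on the pyridine ring would be needed to test it.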